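The source may report more compounds than this note shows. Statements on the series, on what has been measured and on what is new or still open speak of the compounds shown alone.

Compound 3 `COc1cc2c(cc1O)CCC(C)(CC(=O)N[C@H](C(=O)O)C(C)C)O2` holds the second highest of the three numbers in an ADME assay on SH-SY5Y cells (Homo sapiens) for cytotoxicity, read by MTT assay, with a stated time of 24 h, tested at 100 uM (a higher number here means a weaker effect of the compound at the concentration tested, a lower number a stronger effect), where compound 3 gives 61%. Its nearest neighbour is compound 2 `COc1cc2c(cc1O)CCC(C)(CC(=O)N[C@@H](C)C(=O)O)O2`, which in this assay gives 68.5%, and its furthest is compound 1 `COc1cc2c(cc1O)CCC(C)(CC(=O)O)O2`, which in this assay gives 53.1%; both the step of a number 7.5 percentage points lower from compound 2 to compound 3 (within the scatter) and the step of a number 7.9 percentage points higher from compound 1 to compound 3 (within the scatter) lie within the scatter. Compound 4 `COc1cc2c(cc1O)CCC(C)(CC(N)=O)O2` differs from compound 3 in one place: hydrogen in place of 1-carboxy-2-methylpropyl on an amide-type nitrogen. The whole 1-carboxy-2-methylpropyl chain leaves, and the amide-type nitrogen keeps only the carbonyl carbon as a heavy neighbour.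

Within the data shown here, no measured step removes a substituent from that nitrogen, so the guidance is indirect. The step of a number 15.4 percentage points higher from compound 1 to compound 2 (beyond the scatter) is the only one beyond the scatter, while the steps among compounds 1, 2 and 3 otherwise stay within it, so the three numbers sit in a narrow band. On that basis he expects the step of a number 3 percentage points lower from compound 3 to compound 4 (within the scatter) to be small and not beyond the scatter. For compound 4 in this assay he therefore estimates 58%, within a range from 44% to 72%.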

Compound 4, a percentage reported as activity, at one concentration (the size of the read-out at that concentration, not a potency): 51.4%
Compound 4: middle estimate off by 6.6 percentage points, on the high side; measured number inside the range.
By their numbers in this assay, from the lowest: compounds 4, 1, 3 and 2 (each within the scatter of the next, the first and the last beyond it).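

In this assay, taking the whole 1-carboxy-2-methylpropyl chain off the amide-type nitrogen gives a number 9.6 percentage points lower from compound 3 to compound 4 (within the scatter), and amino in place of hydroxy on the carbonyl carbon gives a number 1.7 percentage points lower from compound 1 to compound 4 (within the scatter), so neither change separates these pairs of compounds. The 1-carboxyethyl chain is the one substituent whose loss from this nitrogen registers beyond the scatter, with a number 17.1 percentage points lower from compound 2 to compound 4 (beyond the scatter), a modest step that, together with the earlier step from the acid to the same compound, sets compound 2 apart from both compound 1 and compound 4, while compound 3 stays within the scatter of all three of the others. Nothing in the available evidence accounts for these numbers.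

The compounds shown leave open whether the carboxylic acid of these chains or their carbon part carries the step, which an ethyl or a longer alkyl chain on the nitrogen, or a methyl ester in place of the acid, would begin to separate. They also leave open whether a side chain larger than isopropyl, such as benzyl, would stay within the scatter of compound 3 in this assay.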